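The source may hold more compounds than are shown below. What is called first, only, known or untested is meant among the compounds shown, and "the series" means these compounds.

Series notes, step from compound 1 to compound 4.

Among the measured compounds shown here, compound 1 `Cc1ncc(-c2ccccc2NCC2=NCCN2)o1` is the weakest point of the three measured so far: in a functional assay for activation of Alpha-1A adrenergic receptor (Homo sapiens), read by calcium flux (a lower number here means that less compound is needed, a higher number that more compound is needed for the effect), compound 1 gives 110 nM. Compound 2 `c1ccc(-c2ccccc2NCC2=NCCN2)nc1` gives 6.76 nM in this assay, and compound 3 `c1ccc(-c2cnccn2)c(NCC2=NCCN2)c1` gives 4.57 nM. The two measured steps from compound 1 are both large: a 16-fold lower number from compound 1 to compound 2 (1.21 log units; beyond the scatter) and a 24-fold lower number from compound 1 to compound 3 (1.38 log units; beyond the scatter). Between the two better compounds the step is small, a 1.5-fold lower number from compound 2 to compound 3 (0.17 log units; within the scatter).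

Compound 4 `CC/C(=N\OC)c1ccccc1NCC1=NCCN1` is not yet measured. Its change from compound 1 is a group of 6 heavy atoms (4 carbon, 1 nitrogen, 1 oxygen; no ring) in place of a group of 6 heavy atoms (4 carbon, 1 nitrogen, 1 oxygen; one five-membered aromatic ring with 2 hetero atoms), on an aromatic carbon

Both measured steps swap the 2-methyl-1,3-oxazol-5-yl group for a six-membered aromatic ring; the group entering in compound 4 has no ring and carries a double bond outside aromatic rings, so neither step speaks directly to it. What the measured steps do show is that the 2-methyl-1,3-oxazol-5-yl group of compound 1 sits at the unfavourable end, and that its removal has so far always helped. On that basis a moderate step downward in this assay is expected for compound 4, a 2.2-fold lower number from compound 1 to compound 4 (0.34 log units; beyond the scatter), with a wide range allowed for because no acyclic group has been measured here. The estimate for compound 4 is 50 nM, with a range of 12 nM to 250 nM.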

Compound 4, half-maximal effective concentration: 3.31 nM
Compound 4: the middle estimate sits 15-fold (1.18 log units) above what was measured; measured number below the stated range.
By their numbers in this assay, from the lowest: compounds 4, 3 and 2 (each within the scatter of the next, the first and the last beyond it); then compound 1.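

In this assay a ring is not required at this position: the group with no ring and one double bond outside aromatic rings gives a 33-fold lower number from compound 1 to compound 4 (1.52 log units; beyond the scatter) and so moves the same way as the two replacements by six-membered aromatic rings. Against those rings the acyclic group shows no loss: a 1.4-fold lower number from compound 3 to compound 4 (0.14 log units; within the scatter) stays within the scatter, and a 2.0-fold lower number from compound 2 to compound 4 (0.31 log units; beyond the scatter) is a modest step just beyond it. The leaving and entering groups match in their counts of heavy atoms and hydrogen-bond acceptors, and nothing measured here accounts for the large step from the 2-methyl-1,3-oxazol-5-yl group.

Still open, going by these compounds, is whether the double bond itself matters, which a saturated alkyl chain or a simple ether on the same aromatic carbon would address, along with a shorter methyl or a longer propyl chain in the entering group. Also open, on these data alone, is how an amine or a carboxylic acid at this place would behave in this assay and whether the flat range among compound 2, compound 3 and compound 4 extends to such groups.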